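This account rests on a few compounds, and the source may have more. Where it says the series, first, only, none or still open, it means among the compounds named here.

In a functional assay on T98G cells (Homo sapiens) for inhibition, read by MTT assay, with a stated time of 72 h (a lower number here means a stronger inhibitor, a higher number a weaker inhibitor), compound 1 `CCNC(=S)NC1CC(C)(C)Oc2ccc(Cl)cc21` gives > 100000 nM, which is a limit of the assay and not a number. For the measured compounds named here, compound 2 `CC1(C)CC(NC(=S)Nc2ccccc2)c2cc(Cl)ccc2O1` gives 37000 nM, the only actual number so far. It carries phenyl in place of ethyl on an amide-type nitrogen. Going by the values given here, the one measured step, an at least 2.7-fold lower number from compound 1 to compound 2 (0.43 log units; beyond the scatter), is bounded by the limit of > 100000 nM in this assay, at which 1 of the 2 values shown sits, so it fixes a minimum size only.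

Compound 3 `CC1(C)CC(NC(=S)Nc2cccc(C#N)c2)c2cc(Cl)ccc2O1` keeps everything in compound 2 except for cyano in place of hydrogen on an aromatic carbon, which reads as phenyl to 3-cyanophenyl: cyano in place of hydrogen on an aromatic carbon. Among the compounds with values here, no measured step alters a substituent on that aromatic ring, so the step to compound 2 gives only indirect guidance. That step, an at least 2.7-fold lower number from compound 1 to compound 2 (0.43 log units; beyond the scatter), shows that changing this group can move the number in this assay beyond the scatter, and it suggests a modest step at most. A lower number is expected, though with low confidence, and the estimated step is a 1.9-fold lower number from compound 2 to compound 3 (0.27 log units; within the scatter). Compound 3 is expected at 20000 nM, with an estimated range of 7000 nM to 60000 nM.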

Compound 3, half-maximal inhibitory concentration: 10000 nM
Estimate against measurement, compound 3: 2.0-fold (0.30 log units) above; low and high end bracket the measured number.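

In this assay, cyano in place of hydrogen on an aromatic carbon gives a 3.7-fold lower number from compound 2 to compound 3 (0.57 log units; beyond the scatter), so the aromatic ring itself, and not only the exchange of ethyl for phenyl, is a place where the number moves beyond the scatter. Measured against the ethyl compound, the change to 3-cyanophenyl gives an at least 10-fold lower number from compound 1 to compound 3 (1.00 log units; beyond the scatter), which fixes a minimum size only, since compound 1 stands at a limit and not a number: the limit of > 100000 nM in this assay, at which 1 of the 3 values shown sits.

Compound 3 is the strongest inhibitor of the three shown, with its steps to both others printed as beyond the scatter, and it gives 10000 nM in this assay.

With one substituent at one place on this ring, the compounds shown leave open whether the drop in the number belongs to cyano in particular or would also follow from a methoxy group, a chlorine or a carboxylic acid at the same carbon. They also leave open what cyano does at other carbons of the ring, and whether it would act alike on a ring other than this phenyl.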